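Phenyl to 2-fluorophenyl on compound 1

The source may hold more compounds than are shown below. What is called first, only, known or untested is meant among the compounds shown, and "the series" means these compounds.

In an ADME assay on MT4 cells (Homo sapiens) for cytotoxicity, read by MTT assay, with a stated time of 4 days (a lower number here means that less compound is tolerated, a higher number that more compound is tolerated), compound 1 `CC(=O)Nc1ccc(O)c(C(=O)/C=C/c2ccccc2)c1` gives 49400 nM. For the measured compounds named here, compound 2 `COc1cccc(/C=C/C(=O)c2cc(NC(C)=O)ccc2O)c1`, the only other measured member of the series, gives 40000 nM. The two values lie within the scatter of each other, so compound 1 has no clear rank against compound 2.

Compound 3 `CC(=O)Nc1ccc(O)c(C(=O)/C=C/c2ccccc2F)c1` differs from compound 1 in one place: fluoro in place of hydrogen on an aromatic carbon. This is fluoro in place of hydrogen on an aromatic carbon, ortho to a large group, which turns phenyl into 2-fluorophenyl.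

Going by the values given here, no measured compound carries fluoro, so the evidence is indirect. Among the compounds with values here, the only measured step that bears on the change is methoxy in place of hydrogen on an aromatic carbon, a 1.2-fold lower number from compound 1 to compound 2 (0.09 log units; within the scatter). One step is a thin basis, but it gives no reason to expect a shift beyond the scatter in this assay, and no direction is expected either. The estimated step is a 1.1-fold lower number from compound 1 to compound 3 (0.06 log units; within the scatter). For compound 3 the expected value is 43000 nM, with an estimated range of 22000 nM to 85000 nM.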

Compound 3, half-maximal cytotoxic concentration: 33800 nM
The estimate for compound 3 lay 1.3-fold (0.10 log units) above the measured number, within the range that was stated.
By their numbers in this assay, from the lowest: compounds 3, 2 and 1 (each within the scatter of the next).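

Fluoro in place of hydrogen on an aromatic carbon, ortho to a large group, now has a direct reading in this assay: the change gives a 1.5-fold lower number from compound 1 to compound 3 (0.16 log units; within the scatter), so this position accepts fluoro with no shift that can be told from the scatter. For the compounds shown here, until now, the only reading of a single change to this series was the methoxy step, a 1.2-fold lower number from compound 1 to compound 2 (0.09 log units; within the scatter), and the fluoro step now gives a second case, with a different group, that stays within the scatter. Nothing measured here bears on why the number holds, and the result stands as an observation only.

Going by these compounds, whether this position stays as undemanding with a group unlike fluoro remains open: an amine, a carboxylic acid or a longer chain such as n-butyl in place of the fluoro could still move the number beyond the scatter. A single step also cannot separate a small real change from repeat-to-repeat variation, so a fluoro effect of that size in either direction is neither shown nor excluded.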